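This account rests on a few compounds, and the source may have more. Where it says the series, first, only, none or still open, it means among the compounds named here.

Series notes, step from compound 2 to compound 4.

Going by the values given here, compound 2 `Cc1nc(Cl)ncc1C(=O)Nc1cc(C(F)(F)F)cc(C(F)(F)F)c1` is the only member with a numeric reading: in an assay on Jurkat cells for activation of nuclear factor NF-kappa-B complex (Homo sapiens) (a lower number here means a stronger inhibitor, a higher number a weaker inhibitor), compound 2 gives 50 nM. Compound 1 `N#Cc1ncc(C(=O)Nc2cc(C(F)(F)F)cc(C(F)(F)F)c2)c(C(F)(F)F)n1` stops at a limit, giving > 10000 nM in this assay. Compound 3 `Cc1nc(C(F)(F)F)ncc1C(=O)Nc1cc(C(F)(F)F)cc(C(F)(F)F)c1` likewise stops at a limit, giving > 10000 nM in this assay. Among the compounds with values here, the one measured step, an at least 200-fold higher number from compound 2 to compound 3 (2.30 log units; beyond the scatter), is read against (the limit of > 10000 nM in this assay, at which 2 of the 3 values shown sit), so its full size stays open.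

Compound 4 `O=C(Nc1cc(C(F)(F)F)cc(C(F)(F)F)c1)c1cnc(Cl)cn1` differs from compound 2 by 5-chloropyrazin-2-yl in place of 2-chloro-4-methylpyrimidin-5-yl on a carbonyl carbon. Within the data shown here, the chloro that was exchanged between compound 2 and compound 3 is kept in compound 4, so the measured step bears on the new compound only in showing that the chloro is not to be given up; no measured step covers the loss of the methyl or the change of ring. The expectation is a step of a 4.0-fold higher number from compound 2 to compound 4 (0.60 log units; beyond the scatter) in this assay, toward a weaker inhibitor by a moderate amount, with wide uncertainty either way. Compound 4 is therefore estimated at 200 nM, between 30 nM and 3000 nM, in this assay.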

Compound 4, half-maximal inhibitory concentration: 4000 nM
Beside the measured number, compound 4's estimate is 20-fold (1.30 log units) below it; the whole stated range lies below it.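

In this assay, 5-chloropyrazin-2-yl in place of 2-chloro-4-methylpyrimidin-5-yl on the carbonyl carbon gives an 80-fold higher number from compound 2 to compound 4 (1.90 log units; beyond the scatter), so keeping the chloro does not on its own preserve the reading of compound 2. Going by these compounds alone, the group on this carbonyl carbon is therefore sensitive to more than the exchange of the chloro, the only change that the earlier step tested. Compound 4 also gives a numeric reading, so this step has a full size, whereas other steps in the series run into the assay limit: the limit of > 10000 nM in this assay, at which 2 of the 4 values shown sit.

The step changes the ring and removes the methyl together, so the share of each stays unresolved. Also open, as far as these compounds go, is what an amine or a methoxy group in place of the chloro would do on either ring.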